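Ester-bearing thioether amides: cytotoxicity on CEM-SS cells

This account rests on a few compounds, and the source may have more. Where it says the series, first, only, none or still open, it means among the compounds named here.

Compound 1 `CCCC(=O)OCSc1ccccc1C(=O)NCCCNC(C)=O` is the reference point of this set. For the measured compounds named here, in an ADME assay on CEM-SS cells (Homo sapiens) for cytotoxicity, read by XTT assay, with a stated time of 6 days (on this read-out lower numbers stand for higher toxicity in this test and higher numbers for lower toxicity in this test), compound 1 gives 21.1 uM, the only number recorded for it, with one further entry that carries no single number. Compound 2 `CCCC(=O)OCSc1ccccc1C(=O)N[C@H]1CCC[C@H]1C(N)=O` has been run more than once in this assay and gives 89.9 uM; 84.8 uM (2 entries); the repeated entries agree within the scatter (the several entries of compound 2 in this assay, 89.9 uM; 84.8 uM (2 entries)). Going by the values given here, no step between measured compounds is available, so the pair of compounds 1 and 2 is read only as two values.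

Compound 3 `CCCC(=O)OCSc1ccccc1C(=O)NCC(=O)NCC(=O)OC` has not yet been measured in this assay. It differs from compound 1 in one place: ((methoxycarbonyl)methyl)carbamoyl in place of 2-acetamidoethyl on a saturated chain carbon bound to an amide-type nitrogen. For compound 3 the change is expected to shift this assay little, with a step from compound 1 a 1.7-fold higher number from compound 1 to compound 3 (0.22 log units; within the scatter) that is estimated to stay at or just beyond the scatter, in the direction of lower toxicity. Compound 3 is therefore expected to give about 35 uM, with a range from 12 uM to 100 uM.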

Compound 3, half-maximal toxic concentration: > 100 uM
Compound 3 gave a limit, no number (the forecaster's own chance of this, stated with the estimate: 25%); middle value at least 2.8-fold (0.45 log units) from the limit.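

Placing ((methoxycarbonyl)methyl)carbamoyl in place of 2-acetamidoethyl on a saturated chain carbon bound to an amide-type nitrogen gives the only step in the series so far in this assay: an at least 4.7-fold higher number from compound 1 to compound 3 (0.67 log units; beyond the scatter). This shows that the change at this position moves the read-out beyond the scatter, towards lower toxicity in this test. In this assay compound 3 gives > 100 uM, which is a limit and not a number.

As far as these compounds go, the full size of the step stays unknown because only a minimum can be read from a limit: the limit of > 100 uM in this assay, at which 1 of the 3 values shown sits. Also open, from the compounds shown here alone, is whether the methoxycarbonyl group or the added carbamoyl carries the step, and whether a carboxylic acid or a primary amine in place of the methoxycarbonyl group would give the same result.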